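Furan-2-yl for phenyl on the longer-chain amide

The compounds below may be only part of what the source reports. "The series", "measured", "known", "first", "only" and "open" are said of these compounds alone.

Measured compounds in this assay:
compound 1 `CCCCCCCCCCCCNC(=O)[C@@H](NC(=O)c1ccccc1)[C@@H](C)O` gives 41200 nM
compound 2 `CCCCCCCCCCCCNC(=O)[C@@H](NC(=O)c1ccco1)[C@@H](C)O` gives 92400 nM
compound 3 `CCCCCCCCCCCCCCNC(=O)[C@@H](NC(=O)c1ccccc1)[C@@H](C)O` gives 118000 nM

In a functional assay on A-431 cells (Homo sapiens) for cytotoxicity, read by MTT assay, with a stated time of 48 h (on this read-out higher numbers stand for weaker inhibition and lower numbers for stronger inhibition), compound 1 gives 41200 nM, and a 2.2-fold higher number from compound 1 to compound 2 (0.35 log units; beyond the scatter), the change being (furan-2-yl in place of phenyl on a carbonyl carbon). The core of compound 3 differs from the core of compound 1 by ethyl in place of hydrogen on a saturated chain carbon, ten or more bonds along the chain from an amide-type nitrogen, and a 2.9-fold higher number from compound 1 to compound 3 (0.46 log units; beyond the scatter). The values of compound 2 and compound 3 lie within the scatter of each other. Compound 4 `CCCCCCCCCCCCCCNC(=O)[C@@H](NC(=O)c1ccco1)[C@@H](C)O` is not yet measured; it differs from compound 3 by furan-2-yl in place of phenyl on a carbonyl carbon, the same change as from compound 1 to compound 2, at the same place. The step is expected to be a 2.1-fold higher number from compound 3 to compound 4 (0.33 log units; beyond the scatter), because a 2.2-fold higher number from compound 1 to compound 2 (0.35 log units; beyond the scatter). Compound 4 is expected near 250000 nM, estimated between 110000 nM and 600000 nM, with a real chance the assay reports only a limit.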

Compound 4, half-maximal inhibitory concentration: 190000 nM
Estimate against measurement, compound 4: 1.3-fold (0.12 log units) above; the measured number falls inside the stated range.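

In this assay, furan-2-yl in place of phenyl on the core of compound 3 gives a 1.6-fold higher number from compound 3 to compound 4 (0.21 log units; within the scatter), and this step agrees with the one on the core of compound 1: the same change on two cores in this assay, a 2.2-fold higher number (0.35 log units; beyond the scatter) from compound 1 to compound 2 and a 1.6-fold higher number (0.21 log units; within the scatter) from compound 3 to compound 4, 1.4-fold (0.14 log units) apart, within the scatter of two such steps. Ethyl in place of hydrogen on the saturated chain, read with furan-2-yl present, gives a 2.1-fold higher number from compound 2 to compound 4 (0.31 log units; beyond the scatter), and this agrees with the same change read with phenyl present: the same change on two cores in this assay, a 2.9-fold higher number (0.46 log units; beyond the scatter) from compound 1 to compound 3 and a 2.1-fold higher number (0.31 log units; beyond the scatter) from compound 2 to compound 4, 1.4-fold (0.14 log units) apart, within the scatter of two such steps. Both changes therefore carry across these four compounds, though two cores cannot show that either would carry to other cores, and the step on compound 3 alone would not separate the two groups.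

Open, on these data alone, is how an amine or a carboxylic acid on the carbonyl carbon would read. As far as these compounds go, a longer chain also remains open.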